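Series notes: methoxy in place of hydroxy on compound 2

The source may hold more compounds than are shown below. What is called first, only, known or untested is meant among the compounds shown, and "the series" means these compounds.

compound 1, `Cc1nn(-c2cccc3cc(Cc4cccc(C(F)(F)F)c4)sc23)cc1C(=O)NCCO`: 102%
compound 2, `Cc1nn(-c2cccc3cc(Cc4cccc(C(F)(F)F)c4)sc23)c(C)c1C(=O)NCCO`: 110%

Both numbers come from a functional assay on CHO cells for agonist activity at G-protein coupled receptor 52 (Homo sapiens), read by AlphaScreen and cAMP accumulation, with a stated time of 30 min; on this read-out higher numbers stand for larger maximal responses and lower numbers for smaller maximal responses. In this assay compound 1 gives 102% and compound 2 gives 110%; the two values lie within the scatter of each other, so neither compound can be set above the other. Among the compounds with values here, the single measured step, a number 8 percentage points higher from compound 1 to compound 2 (within the scatter), is likewise within the scatter.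

Compound 3, `COCCNC(=O)c1c(C)nn(-c2cccc3cc(Cc4cccc(C(F)(F)F)c4)sc23)c1C`, differs from compound 2 by methyl in place of hydrogen on an oxygen on a saturated carbon. Within the data shown here, no measured step concerns the hydroxy to methoxy change; the only step available, a number 8 percentage points higher from compound 1 to compound 2 (within the scatter), concerns methyl in place of hydrogen on an aromatic carbon and stays within the scatter. Nothing in the numbers therefore points to a shift beyond the scatter, and the expected step is a number 5 percentage points lower from compound 2 to compound 3 (within the scatter), essentially no change. For compound 3 the estimate is 105%, with a range from 85% to 125%.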

Compound 3, largest response reached (Emax), in percent of the reference or control that the assay uses: 104%
Compound 3: middle estimate off by 1 percentage points, on the high side; low and high end bracket the measured number.
By their numbers in this assay, from the lowest: compounds 1, 3 and 2 (each within the scatter of the next).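

In this assay, 2-methoxyethyl in place of 2-hydroxyethyl gives a number 6 percentage points lower from compound 2 to compound 3 (within the scatter). Compounds 1 and 2 both carry the 2-hydroxyethyl chain, so only compound 3 shows that a response of this size does not require the hydrogen on that oxygen: with methyl there, compound 3 gives 104% in this assay. No available measurement offers an explanation for this result.

Still open, as far as these compounds go, is how a carboxylic acid or an amine in place of the hydroxy, or a longer chain carrying the methoxy, would read in this assay. Also open, from the compounds shown here alone, is whether the hydroxy to methoxy change reads the same on compound 1, and whether potency follows the largest response seen here.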